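Swapping the oxazolidinone of compound 1 for a thiazole

The compounds below may be only part of what the source reports. "The series", "measured", "known", "first", "only" and "open" are said of these compounds alone.

Values in a physicochemical assay for solubility; a higher number here means a more soluble compound, a lower number a less soluble compound:
- compound 1 `O=C1OCCN1c1cc(C(F)(F)F)ccc1[C@H]1CCOc2cc(S(=O)(=O)Nc3nccs3)ccc21`: 295000 nM
- compound 2 `O=S(=O)(Nc1ncccn1)c1ccc2c(c1)CC[C@@H]2c1ccc(C(F)(F)F)cc1-c1ccc(F)nc1`: 40000 nM
- compound 3 `Cn1nccc1-c1cc(C(F)(F)F)ccc1[C@H]1CCOc2cc(S(=O)(=O)Nc3cccc(F)n3)ccc21`: 27000 nM

Compound 1 stands highest of the three in this assay, and its gaps to compound 2 and compound 3 both lie beyond the scatter. Those two lower compounds lie within the scatter of each other.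

The next compound to be read is compound 4 `O=S(=O)(Nc1nccs1)c1ccc2c(c1)OCC[C@@H]2c1ccc(C(F)(F)F)cc1-c1nccs1`. It keeps the core of compound 1 and changes one group on an aromatic carbon: 1,3-thiazol-2-yl in place of 2-oxo-1,3-oxazolidin-3-yl (1,3-thiazol-2-yl in place of 2-oxo-1,3-oxazolidin-3-yl on an aromatic carbon).

Among the measured compounds shown here, no two measured compounds differ in only one place, so the size of this step has no direct precedent. For the measured compounds named here, the only guide is indirect. Neither compound 2 at 40000 nM nor compound 3 at 27000 nM carries 2-oxo-1,3-oxazolidin-3-yl, and each holds an aromatic ring at that place, though both also differ from compound 1 elsewhere. A clear fall beyond the scatter is therefore expected, with wide uncertainty.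

The expected change is a 6.6-fold lower number from compound 1 to compound 4 (0.82 log units; beyond the scatter). For compound 4 the estimated value is 45000 nM, with an expected range from 12000 nM to 150000 nM.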

Compound 4, solubility: 15000 nM
Compound 4: the middle estimate sits 3.0-fold (0.48 log units) above what was measured; low and high end bracket the measured number.
By their numbers in this assay, from the lowest: compounds 4, 3 and 2 (each within the scatter of the next, the first and the last beyond it); then compound 1.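

In this assay, among the compounds shown here, the step of a 20-fold lower number from compound 1 to compound 4 (1.29 log units; beyond the scatter), a large one, is the first reading of this position with the rest of the structure held fixed. The lower values of compound 2 and compound 3 could not be assigned to this place. Both of these compounds also differ from compound 1 elsewhere. The change on this aromatic carbon, ortho to a large group and meta to a trifluoromethyl group, is therefore enough on its own to produce a step beyond the scatter, even though 2-oxo-1,3-oxazolidin-3-yl and 1,3-thiazol-2-yl have matching counts of hydrogen-bond donors and acceptors and differ by only one heavy atom, with the non-aromatic ring and its double bond outside aromatic rings replaced by an aromatic ring. No measurement here bears on why the step has this size.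

The compounds shown leave open whether a non-aromatic ring without the carbonyl, such as morpholine, or an open-chain amine, such as dimethylamino, would read closer to compound 1 or to compound 4. They also leave open whether the same exchange gives a step of similar size on another core.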